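From a Dimethoxyphenyl Amide to a Fluorophenyl Amide

The compounds below may be only part of what the source reports. "The series", "measured", "known", "first", "only" and "open" are said of these compounds alone.

Compound 1, `COc1ccc(C(=O)c2cc(OC)c(OC)c(OC)c2)cc1N`: 2100 nM
Compound 2, `COc1ccc(C(=O)c2cc(OC)c(OC)c(OC)c2)cc1NC(=O)/C=C/c1ccc(OC)c(OC)c1`: 10200 nM

Both measurements come from a functional assay on DU-145 cells (Homo sapiens) for cytotoxicity, read by MTT assay, with a stated time of 72 h; on this read-out lower numbers stand for stronger inhibition and higher numbers for weaker inhibition. In this assay compound 1 gives 2100 nM, and compound 2 gives 10200 nM, the higher of the two numbers; the gap between them lies beyond the usual scatter, so compound 2 is the weaker of the pair. Among the compounds with values here, no single-point step links compound 1 and compound 2, so only their two values can be set side by side.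

Compound 3, `COc1ccc(C(=O)c2cc(OC)c(OC)c(OC)c2)cc1NC(=O)/C=C/c1ccc(F)cc1`, has not been measured yet. It differs from compound 2 in one place: 4-fluorophenyl in place of 3,4-dimethoxyphenyl on a double-bonded chain carbon bound to a double-bonded chain carbon. The group that leaves and the group that enters are each one six-membered aromatic ring of carbon only; what changes is what hangs on that ring.

Nothing measured here shows what this kind of exchange does, so the expectation rests on compound 2 alone and carries a wide range. The step from compound 2 to compound 3 is expected to be small, a 1.3-fold lower number from compound 2 to compound 3 (0.11 log units; within the scatter), leaning slightly toward a lower number but not clearly beyond the scatter. Compound 3 is expected to give about 8000 nM in this assay, within a range of 3000 nM to 25000 nM.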

Compound 3, half-maximal inhibitory concentration: 3900 nM
Compound 3: middle estimate off by 2.1-fold (0.31 log units), on the high side; measured number inside the range.
By their numbers in this assay, from the lowest: compounds 1 and 3 (each within the scatter of the next); then compound 2.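

In this assay, exchanging the 3,4-dimethoxyphenyl ring of compound 2 for the 4-fluorophenyl ring of compound 3 gives a 2.6-fold lower number from compound 2 to compound 3 (0.42 log units; beyond the scatter), the first sign that what hangs on this aromatic ring can shift the result. Placing the whole (2-(4-fluorophenyl)ethenyl)carbonyl group instead of hydrogen on the nitrogen on the aromatic ring gives a 1.9-fold higher number from compound 1 to compound 3 (0.27 log units; within the scatter), and since this step stays within the usual scatter, compound 1 and compound 3 cannot be told apart here, even though the group added to compound 1 is a large one. The data offer nothing that explains why the ring exchange has this effect.

The exchange removes both methoxy groups and adds a fluorine in one step, so the compounds shown cannot say which of these changes matters, and a plain phenyl ring or a 4-methoxyphenyl ring would help to separate them. Going by these compounds, it also remains open whether a different group at the same ring position, such as chlorine, a nitrile or an amine, would give a number clearly lower than that of compound 1.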